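This account rests on a few compounds, and the source may have more. Where it says the series, first, only, none or still open, it means among the compounds named here.

Measured so far:
compound 1, `Clc1ccc(Nc2nccc(-c3ccc(Cl)cc3Cl)n2)c(Cl)c1`: in an assay on isolated protein for inhibition of phosphatidylinositol 4,5-bisphosphate 3-kinase catalytic subunit beta isoform (Homo sapiens) (on this read-out higher numbers stand for weaker inhibition and lower numbers for stronger inhibition), compound 1 gives 799 nM
compound 2, `O=[N+]([O-])c1ccc(Nc2nccc(-c3ccc(Br)cc3)n2)cc1`: compound 2 gives 961 nM
compound 3, `COc1cccc(Nc2nccc(-c3ccc(Cl)c(Cl)c3)n2)c1`: compound 3 gives 741 nM

Compound 2 carries the highest of the three numbers, but its gaps to compound 1 and to compound 3 both lie within the scatter, so no ranking among the three follows from these values.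

Compound 4, `O=[N+]([O-])c1ccc(Nc2nccc(-c3ccc(Cl)c(Cl)c3)n2)cc1`, differs from compound 2 in one place: 3,4-dichlorophenyl in place of 4-bromophenyl on an aromatic carbon. Among the measured compounds shown here, no pair of measured compounds isolates this change, so no measured step speaks to it directly. Compound 3 carries the same 3,4-dichlorophenyl, on a different amine, and its number sits close to that of compound 2, which suggests nothing beyond the scatter.

In this assay the step is expected to stay within the scatter, estimated as a 1.2-fold lower number from compound 2 to compound 4 (0.08 log units; within the scatter). Compound 4 is estimated at 800 nM, with a range from 350 nM to 1900 nM.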

Compound 4, half-maximal inhibitory concentration: 573 nM
Compound 4: middle estimate off by 1.4-fold (0.14 log units), on the high side; low and high end bracket the measured number.
By their numbers in this assay, from the lowest: compounds 4, 3, 1 and 2 (each within the scatter of the next).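

With the rest of the molecule held constant, 3,4-dichlorophenyl in place of 4-bromophenyl gives a 1.7-fold lower number from compound 2 to compound 4 (0.22 log units; within the scatter) in this assay. Among the compounds shown here, this is the first single-place comparison at this position, and it shows that these two halogenated phenyl groups can be exchanged there without a step beyond the scatter. No supporting data bear on the reason for this step.

Open, going by these compounds, is whether a different kind of group at this position, such as an unsubstituted phenyl, a morpholine or a carboxylic acid, would move the number beyond the scatter.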